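Taking one fluoro group off compound 2

This account rests on a few compounds, and the source may have more. Where it says the series, first, only, none or still open, it means among the compounds named here.

In a physicochemical assay for acid dissociation, read by spectrophotometry, in phosphate buffer, at pH 4.3, tested at 0.1 mM, compound 1 (`OB(O)c1cccc(-n2cc(-c3ccsc3)nn2)c1`) gives 8.31 and compound 2 (`OB(O)c1cc(-n2cc(-c3ccsc3)nn2)c(F)cc1F`) gives 6.27 as the lower of the two numbers, a gap beyond the scatter. Compound 3 (`OB(O)c1cc(-n2cc(-c3ccsc3)nn2)ccc1F`) has hydrogen in place of fluoro on an aromatic carbon. Among the compounds with values here, no measured pair shows this change alone, so the expectation rests on compound 2 at 6.27 and compound 1 at 8.31 as its two ends. A rise beyond the scatter is expected in this assay that recovers part of that gap. The estimated step (a number 0.93 log units higher from compound 2 to compound 3 (beyond the scatter)) is upward. The estimate for compound 3 is 7.2 (range 6.8 to 7.7).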

Compound 3, acid dissociation constant: 7.61
The estimate for compound 3 lay 0.41 log units below the measured number; the range from low to high includes it.
By their numbers in this assay, from the lowest: compound 2; then compound 3; then compound 1.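

In this assay the fluoro group ortho to a large group proves to matter on its own: hydrogen in its place gives a number 1.34 log units higher from compound 2 to compound 3 (beyond the scatter), a large step. The other fluoro group also matters alone, since fluoro in place of hydrogen gives a number 0.70 log units lower from compound 1 to compound 3 (beyond the scatter), a modest step. Nothing shown here accounts for either step. The compounds shown leave open whether chloro or methoxy on this aromatic carbon would move the number the same way.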